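The source may report more compounds than this note shows. Statements on the series, on what has been measured and on what is new or still open speak of the compounds shown alone.

Compound 1 `C/C=C/C=C/C(=O)N[C@H](C(=O)NCCCCCCCCCCCC)[C@@H](C)O` carries a saturated chain on an amide-type nitrogen and a (penta-1,3-dien-1-yl)carbonyl group on an amine nitrogen. In a functional assay on SW-620 cells (Homo sapiens) for cytotoxicity, read by MTT assay, with a stated time of 48 h (on this read-out higher numbers stand for weaker inhibition and lower numbers for stronger inhibition), compound 1 gives 200000 nM. Compound 2 `CCCCCCCCCCCCNC(=O)[C@@H](NS(=O)(=O)c1ccc(C)cc1)[C@@H](C)O` differs from it in one place, ((4-methylphenyl)sulfonyl in place of (penta-1,3-dien-1-yl)carbonyl on an amine nitrogen), and in this assay compound 2 gives 25600 nM, which is a 7.8-fold lower number from compound 1 to compound 2 (0.89 log units; beyond the scatter). Compound 3 `C/C=C/C=C/C(=O)N[C@H](C(=O)NCCCCCCCCCCCCCC)[C@@H](C)O` shares the core of compound 1 except for one counted difference, (ethyl in place of hydrogen on a saturated chain carbon, ten or more bonds along the chain from an amide-type nitrogen); in this assay compound 3 gives 200000 nM, and the step is no change at the digits printed from compound 1 to compound 3 (within the scatter). Compound 4 `CCCCCCCCCCCCCCNC(=O)[C@@H](NS(=O)(=O)c1ccc(C)cc1)[C@@H](C)O` has not yet been measured. It stands to compound 3 as compound 2 stands to compound 1: the difference is (4-methylphenyl)sulfonyl in place of (penta-1,3-dien-1-yl)carbonyl on an amine nitrogen, and the place is worded identically for both pairs, so it is the same change. The ethyl in place of hydrogen made the step of no change at the digits printed from compound 1 to compound 3 (within the scatter), so the expected step is an 8.0-fold lower number from compound 3 to compound 4 (0.90 log units; beyond the scatter), about as large as the earlier one. Compound 4 is therefore estimated at 25000 nM. For compound 4 the expected range runs from 8000 nM to 80000 nM.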

Compound 4, half-maximal inhibitory concentration: 15200 nM
Compound 4: the middle estimate sits 1.6-fold (0.22 log units) above what was measured; the measured number falls inside the stated range.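

Replacing (penta-1,3-dien-1-yl)carbonyl with (4-methylphenyl)sulfonyl on the amine nitrogen gives, in this assay, a 13-fold lower number from compound 3 to compound 4 (1.12 log units; beyond the scatter), and this step on the second core agrees with the one on the first: the same change on two cores in this assay, a 7.8-fold lower number (0.89 log units; beyond the scatter) from compound 1 to compound 2 and a 13-fold lower number (1.12 log units; beyond the scatter) from compound 3 to compound 4, 1.7-fold (0.23 log units) apart, within the scatter of two such steps. Ethyl in place of hydrogen at the far end of the saturated chain gives a 1.7-fold lower number from compound 2 to compound 4 (0.23 log units; within the scatter), so this chain change stays within the scatter whichever group sits on the amine nitrogen: the same change on two cores in this assay, no change at the digits printed (within the scatter) from compound 1 to compound 3 and a 1.7-fold lower number (0.23 log units; within the scatter) from compound 2 to compound 4, 1.7-fold (0.23 log units) apart, within the scatter of two such steps. Across these four compounds, then, each change behaves the same way whatever the other place carries, but two pairs per change are a small test and do not show why the sulfonyl swap lowers the number or that the agreement extends beyond these compounds.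

The compounds shown leave open whether the same agreement would hold with a free amine or a benzoyl group on the amine nitrogen. They also leave open what a much shorter or longer chain on the amide-type nitrogen would do.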